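From Methylsulfonyl to Fluorophenylsulfonyl on a Shared Core

The source may hold more compounds than are shown below. What is called first, only, known or untested is meant among the compounds shown, and "the series" means these compounds.

Compound 2 `CCOC(=O)c1cnc2ccc(-c3cnc(OC)c(NS(C)(=O)=O)c3)cn12` gives 320 nM in a functional assay on HCT-116 cells (Homo sapiens) for antiproliferative activity, read by sulforhodamine B assay, with a stated time of 72 h (a lower number here means a stronger inhibitor, a higher number a weaker inhibitor), the second highest of three numbers: compound 1 `CCOC(=O)c1cnc2ccc(-c3cnc(OC)c(NS(=O)(=O)c4ccc(F)cc4F)c3)cn12` gives 90 nM, and compound 3 `CCOC(=O)c1cc2cc(-c3cnc(OC)c(NS(=O)(=O)c4ccc(F)cc4)c3)ccc2[nH]1`, built on a different core, gives 1300 nM. Compound 4 `CCOC(=O)c1cnc2ccc(-c3cnc(OC)c(NS(=O)(=O)c4ccc(F)cc4)c3)cn12` differs from compound 2 by 4-fluorophenyl in place of methyl on a sulfonyl sulfur. For the measured compounds named here, the one measured step that bears on this change runs the other way: a 3.6-fold higher number from compound 1 to compound 2 (0.55 log units; beyond the scatter). Compound 3 carries the same 4-fluorophenyl group but on another core, so its value alone does not settle this step. Restoring a 4-fluorophenyl group on the sulfonyl sulfur is therefore expected to lower the number, by a step of about a 2.7-fold lower number from compound 2 to compound 4 (0.43 log units; beyond the scatter). Compound 4 is expected to give 120 nM, with a range from 50 nM to 300 nM.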

Compound 4, half-maximal inhibitory concentration: 640 nM
The estimate for compound 4 lay 5.3-fold (0.73 log units) below the measured number, and the stated range ends below it.
By their numbers in this assay, from the lowest: compound 1; then compounds 2 and 4 (each within the scatter of the next); then compound 3.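

Putting 4-fluorophenyl in place of methyl on the sulfonyl sulfur brings a 2.0-fold higher number from compound 2 to compound 4 (0.30 log units; within the scatter) in this assay and so no clear separation: a phenyl ring carrying one fluoro does no better here than methyl. Replacing one fluoro of the 2,4-difluorophenyl group with hydrogen, by contrast, brings a 7.1-fold higher number from compound 1 to compound 4 (0.85 log units; beyond the scatter) and so, among these compounds, the low number of compound 1 goes with that second fluoro and not with the phenyl ring alone.

Whether a chloro group or a methoxy group on the ring could stand in for that fluoro remains open, and no measurement shown explains the fluoro's effect.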